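This account rests on a few compounds, and the source may have more. Where it says the series, first, only, none or still open, it means among the compounds named here.

For the measured compounds named here, in a functional assay on MV4-11 cells (Homo sapiens) for antiproliferative activity, read by CellTiter-Glo, with a stated time of 72 h (a lower number here means a stronger inhibitor of growth, a higher number a weaker inhibitor of growth), only two compounds have been tested so far. Compound 1 `COCCNc1cc(-c2csc(NCC3CCOCC3)n2)c(Cl)cn1` gives > 10000 nM, which is a limit of the assay and not a number. Going by the values given here, compound 2 `N[C@H]1CC[C@H](Nc2cc(-c3csc(NCC4CCOCC4)n3)c(Cl)cn2)CC1` gives 140 nM, the only actual number available, so it is the sole reference point for what follows.

The next compound, compound 3 `CC(=O)N[C@H]1CC[C@H](Nc2cc(-c3csc(NCC4CCOCC4)n3)c(Cl)cn2)CC1`, changes compound 2 at one place: acetyl in place of hydrogen on an amine nitrogen. In other words, 4-aminocyclohexyl becomes 4-acetamidocyclohexyl, while the rest of the structure stays the same.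

Among the compounds with values here, one measured step bears on this change. Putting 4-aminocyclohexyl in place of 2-methoxyethyl gave an at least 71-fold lower number from compound 1 to compound 2 (1.85 log units; beyond the scatter). Compound 3 keeps the cyclohexyl ring from that step but no longer has the free amino group. With a single step as a guide, part of that gain is expected to be lost, giving a higher number, though probably not all of it. The expected change is a 6.4-fold higher number from compound 2 to compound 3 (0.81 log units; beyond the scatter). For compound 3 the estimated value is 900 nM, with an expected range from 200 nM to 5000 nM.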

Compound 3, concentration for 50% growth inhibition: 3600 nM
For compound 3 the middle estimate is 4.0-fold (0.60 log units) below the measured one, and the stated range covers the measured number.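

In this assay, acetyl in place of hydrogen on the amine nitrogen gives a 26-fold higher number from compound 2 to compound 3 (1.41 log units; beyond the scatter), so most of what compound 2 gained over compound 1 depends on that nitrogen staying uncapped, and the cyclohexyl ring alone does not account for it. Some gain still remains without the free amine, with 4-acetamidocyclohexyl in place of 2-methoxyethyl giving an at least 2.7-fold lower number from compound 1 to compound 3 (0.44 log units; beyond the scatter), which shows that the amide is still better tolerated here than the ether chain. That second step is only a bound, since the value for compound 1 is a limit of the assay and not a number: the limit of > 10000 nM in this assay, at which 1 of the 3 values shown sits.

The compounds shown leave open whether the amine hydrogens themselves matter or the added acetyl is what costs growth inhibition, a question that a methylamino or dimethylamino group at the same place on the cyclohexyl ring would help to separate. They also leave open how much the cyclohexyl ring contributes beyond carrying the amine, which a simple 2-aminoethyl chain in place of 2-methoxyethyl would test.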